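Selenium-Bridged Bis-Acylisoselenourea Series: Cytotoxicity Working Notes

The source may hold more compounds than are shown below. What is called first, only, known or untested is meant among the compounds shown, and "the series" means these compounds.

Measured compounds:
compound 1, `O=C(/N=C(/NC(=O)c1cccs1)[Se]Cc1ccccc1)c1cccs1`: 81500 nM
compound 2, `C[Se]/C(=N\C(=O)c1cnc2ccccc2c1)NC(=O)c1cnc2ccccc2c1`: 87800 nM

In a functional assay on HepG2 cells (Homo sapiens) for cytotoxicity, read by MTT assay, with a stated time of 72 h (a higher number here means that more compound is tolerated, a lower number that less compound is tolerated), compound 1 gives 81500 nM. In this assay compound 2 gives 87800 nM. The two numbers lie within the scatter of each other, so no order between compound 1 and compound 2 can be read from them.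

Compound 3, `O=C(/N=C(/NC(=O)c1cnc2ccccc2c1)[Se]Cc1ccccc1)c1cnc2ccccc2c1`, carries the change (phenyl in place of hydrogen on a saturated chain carbon bound to a selenium atom). Going by the values given here, no measured pair shows this change in isolation. Compound 1 carries the benzyl group on selenium and compound 2 the methyl, with different amide parts, and both tolerate similar amounts. The step from compound 2 to compound 3 is therefore expected to be a 1.1-fold lower number from compound 2 to compound 3 (0.04 log units; within the scatter), none beyond the scatter in either direction. Compound 3 is expected to give 80000 nM, in the range 40000 nM to 160000 nM.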

Compound 3, concentration lethal to 50% of the cells: 90300 nM
For compound 3 the middle estimate is 1.1-fold (0.05 log units) below the measured one; low and high end bracket the measured number.
By their numbers in this assay, from the lowest: compounds 1, 2 and 3 (each within the scatter of the next).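

In this assay the methyl to benzyl exchange gives a 1.0-fold higher number from compound 2 to compound 3 (0.01 log units; within the scatter), so no difference can be read at this position. Going by these compounds alone, this pair is the first to show phenyl in place of hydrogen on a saturated chain carbon bound to a selenium atom in isolation, with the amide parts held constant. Nothing on hand explains this result.

As far as these compounds go, whether an amine, a carboxylic acid or a longer chain at this position would stay within the same range remains open. From the compounds shown here alone, whether the same change reads alike with the amide parts of compound 1 also remains open.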